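The source may hold more compounds than are shown below. What is called first, only, known or untested is meant among the compounds shown, and "the series" means these compounds.

Measured so far:
compound 1 `COc1ccc(NC(=O)Nc2cccc(CNc3nccnc3Cl)c2)cc1` gives 12000 nM
compound 2 `O=C(Nc1ccc(Cl)cc1)Nc1cccc(CNc2nccnc2Cl)c1` gives 8350 nM
compound 3 `O=C(Nc1cccc(CNc2nccnc2Cl)c1)Nc1ccc(Cl)cc1Cl` gives 7230 nM

All three numbers come from a functional assay on HepG2 cells (Homo sapiens) for antiproliferative activity, read by MTT assay, with a stated time of 48 h; a higher number here means a weaker inhibitor, a lower number a stronger inhibitor. Compound 1 stands at the highest of the three numbers, but both steps away from it, to compound 2 with a 1.4-fold lower number from compound 1 to compound 2 (0.16 log units; within the scatter) and to compound 3 with a 1.7-fold lower number from compound 1 to compound 3 (0.22 log units; within the scatter), lie within the scatter, so the three compounds cannot be ordered.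

Compound 4 `O=C(Nc1cccc(CNc2nccnc2Cl)c1)Nc1ccccc1F` has not yet been measured. From compound 1 it differs in one place: 2-fluorophenyl in place of 4-methoxyphenyl on an amide-type nitrogen. Within the data shown here, the steps that bear on it are the two already made at the same amide-type nitrogen, chloro in place of methoxy on an aromatic carbon and 2,4-dichlorophenyl in place of 4-methoxyphenyl on an amide-type nitrogen, and neither left the scatter. Nothing measured speaks to fluorine on this ring. No step beyond the scatter is therefore expected in this assay, with a slightly lower number if anything. Compound 4 is estimated at 9500 nM, with a range from 4500 nM to 20000 nM. The expected step is a 1.3-fold lower number from compound 1 to compound 4 (0.10 log units; within the scatter).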

Compound 4, half-maximal inhibitory concentration: 10500 nM
Compound 4: middle estimate off by 1.1-fold (0.04 log units), on the low side, and the stated range covers the measured number.
By their numbers in this assay, from the lowest: compounds 3, 2, 4 and 1 (each within the scatter of the next).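

Fluorine on this ring is new, and in this assay the 2-fluorophenyl group on the amide-type nitrogen stays within the scatter of all three earlier aryl groups (a 1.1-fold lower number from compound 1 to compound 4 (0.06 log units; within the scatter); a 1.3-fold higher number from compound 2 to compound 4 (0.10 log units; within the scatter); a 1.5-fold higher number from compound 3 to compound 4 (0.16 log units; within the scatter)). The four compounds, carrying methoxy, chloro, two chloro groups or fluoro on this ring, therefore cannot be ordered, and no change at this position has yet left the scatter. No evidence on hand bears on why these numbers stay together.

Open, on these data alone, is whether a dimethylamino group or a carboxylic acid on this ring, or a longer alkyl chain in place of the ring, would move the number beyond the scatter. Also open, as far as these compounds go, is whether any change to the shared core would do so.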